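The compounds below may be only part of what the source reports. "The series", "measured", "known", "first", "only" and "open" are said of these compounds alone.

Measured so far:
compound 1 `Nc1nc(-c2ccc(Cl)cc2)c(CC(=O)O)s1` — 50%
compound 2 `NS(=O)(=O)c1ccc(-c2nc(C(c3ccc(F)cc3)c3ccc(F)cc3)sc2CC(=O)O)cc1` — 80%
compound 3 `O=C(O)Cc1sc(C(c2ccccc2)c2ccccc2)nc1-c1ccc(F)cc1` — 80%

In an in vitro functional assay on HEK285-7 cells for antagonist activity at prostaglandin D2 receptor 2 (Homo sapiens), read by BRET and beta-arrestin recruitment (a lower number here means a smaller maximal response, a higher number a larger maximal response), compound 1 gives 50%, the lowest of the three numbers. Compound 2 gives 80% and compound 3 gives 80%, and both of these stand above compound 1 by a gap beyond the usual scatter. Going by the values given here, both compound 2 and compound 3 carry larger aromatic groups in place of the small amino group of compound 1, so the three measured numbers hint that a bulkier substituent goes with a larger maximal response, though with only three compounds this is a hint and not a rule.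

Compound 4 `O=C(O)Cc1sc(Cc2ccccc2)nc1-c1ccc(Cl)cc1` has not yet been measured. It differs from compound 1 in one place: benzyl in place of amino on an aromatic carbon. Among the compounds with values here, no measured pair shows exactly this change, so its effect has to be estimated from what the three compounds show. Since compound 4 moves toward the larger aromatic groups of compound 2 and compound 3, an upward step beyond the scatter is expected, a number 20 percentage points higher from compound 1 to compound 4 (beyond the scatter), though smaller than the gap to those two. Compound 4 is therefore expected to reach about 70% in this assay, most likely between 55% and 85%.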

Compound 4, largest response reached (reported as efficacy), in percent of the reference or control that the assay uses: 50%
Compound 4: the middle estimate sits 20 percentage points above what was measured; measured number below the stated range.
By their numbers in this assay, from the lowest: compounds 1 and 4 (each within the scatter of the next); then compounds 2 and 3 (each within the scatter of the next).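

Replacing amino with benzyl on the aromatic carbon next to the ring nitrogen and next to the ring sulfur brings no change at the digits printed from compound 1 to compound 4 (within the scatter) in this assay. Going by these compounds alone, this is the first change that can be read on its own, since the earlier compounds offered no pair differing in one place. It shows that, on the core of compound 1, adding a six-membered aromatic ring of carbon only and losing the hydrogen-bond donor and acceptor of the amino group leave the maximal response unmoved, and nothing available here accounts for this result.

On these data alone, whether a different group at this position, such as a methyl, a longer chain like phenethyl or a dimethylamino group, would shift the response remains open. The compounds shown also leave open whether the swap from amino to benzyl would read the same if a carboxylic acid sat directly on the ring in place of the carboxymethyl group, or if another group replaced the one of 7 heavy atoms.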